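The source may report more compounds than this note shows. Statements on the series, on what has been measured and on what is new or still open speak of the compounds shown alone.

Three hydroxamic acid compounds have been run in a functional assay on MONO-MAC-6 cells (Homo sapiens) for inhibition; on this read-out higher numbers stand for weaker inhibition and lower numbers for stronger inhibition. Compound 1 `C[C@@H](NS(=O)(=O)N1CCC(c2ccc(Cl)cc2)CC1)C(=O)NO` gives 5800 nM. Compound 2 `O=C(NO)[C@H]1CCCCN1S(=O)(=O)N1CC=C(c2cccc(-c3ccccc3)c2)CC1` gives 7600 nM. Compound 3 `O=C(NO)[C@H]1CNCCN1S(=O)(=O)N1CC=C(c2ccc(F)cc2)CC1` gives 3560 nM, the lowest of the three numbers. Set against compound 1, the gap is within the usual scatter of repeated measurements, so those two are best read as alike; set against compound 2, the gap lies beyond the scatter, so compound 3 shows the stronger inhibition of that pair.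

The next compound, compound 4 `CNC(=O)N1CCN(S(=O)(=O)N2CC=C(c3ccc(F)cc3)CC2)[C@@H](C(=O)NO)C1`, has not yet been measured in this assay. It differs from compound 3 in one place: methylcarbamoyl in place of hydrogen on an amine nitrogen in a ring Everything else, the shared core, the hydroxycarbamoyl group and the large group on the ring, stays as it is.

Within the data shown here, no two measured compounds differ in exactly one place, so there is no measured step of this kind to lean on. The expected step is a 1.6-fold lower number from compound 3 to compound 4 (0.21 log units; within the scatter), a shift toward stronger inhibition that is modest and not certain to clear the scatter. On that basis compound 4 is estimated at 2200 nM, with a range from 600 nM to 8000 nM.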

Compound 4, half-maximal inhibitory concentration: 120 nM
For compound 4 the middle estimate is 18-fold (1.26 log units) above the measured one; the measured number lies below the stated range.
By their numbers in this assay, from the lowest: compound 4; then compounds 3, 1 and 2 (each within the scatter of the next, the first and the last beyond it).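

In this assay, among these compounds, methylcarbamoyl in place of hydrogen on the amine nitrogen in the ring gives a 30-fold lower number from compound 3 to compound 4 (1.47 log units; beyond the scatter), a large step well beyond the scatter and the first measured change in a single place. It shows that this position is far from indifferent: the hydrogen on this nitrogen is not needed for inhibition, and a group can sit here while inhibition becomes much stronger, with the hydroxycarbamoyl group and the large group on the ring unchanged. Nothing available here explains why the step is so large.

The compounds shown leave open which part of the methylcarbamoyl group goes with the stronger inhibition, since a plain methyl, an acetyl or a methylsulfonyl group on the same nitrogen would help separate the carbonyl and the amide hydrogen from the rest of the group. They also leave open whether a longer chain on the urea nitrogen, such as ethylcarbamoyl, would keep this strength, and whether the same step would appear with a different large group on the ring.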